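A few compounds are considered here, and "the series" means these few. Any claim that something is new, unique, unknown or untested is made for them only; others in the source may bear on it.

The measured compounds are, in a functional assay on U-87MG ATCC cells (Homo sapiens) for inhibition, read by MTT assay, with a stated time of 72 h; on this read-out lower numbers stand for stronger inhibition and higher numbers for weaker inhibition:

compound 1 `COc1cc2c(Oc3ccc(NC(=O)c4nn(-c5ccccc5C(F)(F)F)c(=O)cc4C)cc3F)ccnc2cc1OCCCN1CCCC1`: 1010 nM
compound 2 `COc1cc2c(Oc3ccc(NC(=O)c4nn(-c5ccccc5C(F)(F)F)c(=O)cc4C)cc3F)ccnc2cc1OCCCN1CCCCC1`: 1150 nM
compound 3 `COc1ccc(-n2nc(C(=O)Nc3ccc(Oc4ccnc5cc(OCCCN6CCCC6)c(OC)cc45)c(F)c3)c(C)cc2=O)cc1`: 2960 nM

Compound 1 and compound 2 share one core and differ only at the end of the chain: piperidin-1-yl in place of pyrrolidin-1-yl on a saturated chain carbon, three bonds along the chain from an oxygen on an aromatic ring. In this assay that change made a 1.1-fold higher number from compound 1 to compound 2 (0.06 log units; within the scatter), so the two compounds cannot be told apart on this read-out.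

Compound 3 carries a different core. The difference between the two cores is 4-methoxyphenyl in place of 2-(trifluoromethyl)phenyl on an aromatic nitrogen, and in this assay it made a 2.9-fold higher number from compound 1 to compound 3 (0.47 log units; beyond the scatter). Compound 3 therefore stands with the highest number of the three, beyond the scatter from both compound 1 and compound 2.

Compound 4 `COc1ccc(-n2nc(C(=O)Nc3ccc(Oc4ccnc5cc(OCCCN6CCCCC6)c(OC)cc45)c(F)c3)c(C)cc2=O)cc1` has not yet been measured. It differs from compound 3 by piperidin-1-yl in place of pyrrolidin-1-yl on a saturated chain carbon, three bonds along the chain from an oxygen on an aromatic ring. The place of this change is described in the same words as for the change from compound 1 to compound 2, so it is the same change, now made on the core of compound 3 instead of the core of compound 1.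

The expectation for compound 4 rests on compound 1 and compound 2, whose step was a 1.1-fold higher number from compound 1 to compound 2 (0.06 log units; within the scatter). On that basis the step to compound 4 is expected to be a 1.1-fold higher number from compound 3 to compound 4 (0.05 log units; within the scatter), again within the scatter. Compound 4 is thus estimated at 3300 nM in this assay, with a range from 1800 nM to 6000 nM expected to cover most repeat measurements.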

Compound 4, half-maximal inhibitory concentration: 1800 nM
Beside the measured number, compound 4's estimate is 1.8-fold (0.26 log units) above it; the range from low to high includes it.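

In this assay, piperidin-1-yl in place of pyrrolidin-1-yl on the core carrying 4-methoxyphenyl gave a 1.6-fold lower number from compound 3 to compound 4 (0.22 log units; within the scatter), and this step cannot be told apart from the one seen with the same change on the core carrying 2-(trifluoromethyl)phenyl: the same change on two cores in this assay, a 1.1-fold higher number (0.06 log units; within the scatter) from compound 1 to compound 2 and a 1.6-fold lower number (0.22 log units; within the scatter) from compound 3 to compound 4, 1.9-fold (0.27 log units) apart, within the scatter of two such steps. The change on the aromatic nitrogen, read with piperidin-1-yl at the end of the chain, gave a 1.6-fold higher number from compound 2 to compound 4 (0.19 log units; within the scatter), whereas with pyrrolidin-1-yl it gave a 2.9-fold higher number from compound 1 to compound 3 (0.47 log units; beyond the scatter), yet the gap between these two steps also stays inside what repeat measurements allow: the same change on two cores in this assay, a 2.9-fold higher number (0.47 log units; beyond the scatter) from compound 1 to compound 3 and a 1.6-fold higher number (0.19 log units; within the scatter) from compound 2 to compound 4, 1.9-fold (0.27 log units) apart, within the scatter of two such steps. Within the data shown here, the ring swap at the chain end therefore carried from one core to the other with no detectable effect on either, but this rests on two small steps on just two cores, so it does not show that the steps are identical or that the result extends to any further core, and the change on the aromatic nitrogen passes the scatter in only one of its two readings.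

The compounds shown leave open how morpholin-4-yl or dimethylamino at the end of the chain, or a chain longer than 3-(piperidin-1-yl)propyl, would read in this assay. They also leave open whether an unsubstituted phenyl on the aromatic nitrogen would follow the same pattern.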